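Methyl on the shared core, cytotoxicity at the assay limit

The source may report more compounds than this note shows. Statements on the series, on what has been measured and on what is new or still open speak of the compounds shown alone.

Measured in an ADME assay on HT-29 cells (Homo sapiens) for cytotoxicity, read by luminescence and CellTiter-Glo, with a stated time of 10 h; a higher number here means that more compound is tolerated, a lower number that less compound is tolerated:
- Compound 1 `CN1C(=O)[C@H](NC(=O)c2n[nH]c(Cc3ccccc3)n2)COc2ncccc21`: > 50000 nM, a limit
- Compound 2 `Cc1ccc2c(n1)OC[C@H](NC(=O)c1n[nH]c(Cc3ccccc3)n1)C(=O)N2C`: > 50000 nM, a limit

Compound 1 has no numeric value in this assay, only the limit > 50000 nM. The same holds for compound 2, whose result is also only a limit, > 50000 nM. Going by the values given here, the whole record so far therefore amounts to the limit of > 50000 nM in this assay, at which 2 of the 2 values shown sit, and no measured step between compounds is available to calibrate a change.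

The next compound to read is compound 3 `Cc1ccc2c(n1)OC[C@@H](NC(=O)c1n[nH]c(Cc3ccccc3)n1)C(=O)N2C`. Its difference from compound 1 is methyl in place of hydrogen on an aromatic carbon, with the rest of the core of compound 1 kept.

Among the compounds with values here, with the limit of > 50000 nM in this assay, at which 2 of the 2 values shown sit, as the only guide, no step beyond the usual scatter is expected in this assay, in either direction. The estimate amounts to a number no higher from compound 1 to compound 3 (the limit leaves the size open), an expected outcome and not a measured one. A report of only a limit is the expected form of the result. For compound 3 the estimated value is 50000 nM, with an expected range from 30000 nM to 100000 nM.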

Compound 3, half-maximal cytotoxic concentration: > 50000 nM
Compound 3: a limit, no number; the forecaster's own chance of this, stated with the estimate: 90%; the middle value lies on the limit itself.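

In this assay compound 3 gives > 50000 nM, which is a limit. No step can be read from compound 1 or compound 2 to compound 3, as all three results stand at the same limit: the limit of > 50000 nM in this assay, at which 3 of the 3 values shown sit.

The compounds shown leave open whether either the added methyl or the change in drawn configuration alters cytotoxicity at all.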